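Trading an Ethoxy for Trifluoromethyl on the Carbonyl

This account rests on a few compounds, and the source may have more. Where it says the series, first, only, none or still open, it means among the compounds named here.

Of the compounds shown here, three built on one shared core have been measured. Compound 1 `COC(=O)N1CCCc2cc(S(=O)(=O)N3CC(c4ccccc4)NC3=O)ccc21` gives 1150 nM in a functional assay on A549 cells (Homo sapiens) for antiproliferative activity, read by MTT assay; on this read-out higher numbers stand for weaker inhibition and lower numbers for stronger inhibition. Compound 2 `CCOC(=O)N1CCCc2cc(S(=O)(=O)N3CC(c4ccccc4)NC3=O)ccc21` gives 344 nM in this assay, and compound 3 `CCCOC(=O)N1CCCc2cc(S(=O)(=O)N3CC(c4ccccc4)NC3=O)ccc21` gives 1030 nM. Compound 2 stands at the lowest number of the three: the step of a 3.3-fold lower number from compound 1 to compound 2 (0.52 log units; beyond the scatter) and the step of a 3.0-fold higher number from compound 2 to compound 3 (0.48 log units; beyond the scatter) both lie beyond the scatter, whereas the step of a 1.1-fold lower number from compound 1 to compound 3 (0.05 log units; within the scatter) does not.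

Compound 4 `O=C1NC(c2ccccc2)CN1S(=O)(=O)c1ccc2c(c1)CCCN2C(=O)C(F)(F)F` has not yet been measured. It differs from compound 2 by trifluoromethyl in place of ethoxy on a carbonyl carbon. Among the compounds with values here, every measured step so far alters only the chain on the oxygen next to the carbonyl group, by adding or removing a methyl, so no step bears directly on replacing that whole ethoxy with trifluoromethyl. What the measured steps do show is that small alterations at this position move the number by modest amounts in either direction. Compound 4 is therefore expected to land somewhat weaker than compound 2, by a 2.3-fold higher number from compound 2 to compound 4 (0.37 log units; beyond the scatter), giving an estimate of 800 nM with a range from 250 nM to 3000 nM.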

Compound 4, half-maximal inhibitory concentration: > 20000 nM
Compound 4 ended at the assay's limit; the forecaster's own chance of this, stated with the estimate: 5%; at least 25-fold (1.39 log units) between middle value and limit.
By their numbers in this assay, from the lowest: compound 2; then compounds 3 and 1 (each within the scatter of the next). At a limit, above all of these: compound 4.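

Compound 4 stands at a limit of the assay, not at a measured number: the limit of > 20000 nM in this assay, at which 1 of the 4 values shown sits. Where changes to the chain on the oxygen moved the number only modestly, replacing the whole group on the carbonyl carbon with trifluoromethyl has a large effect in this assay: an at least 58-fold higher number from compound 2 to compound 4 (1.76 log units; beyond the scatter), an at least 19-fold higher number from compound 3 to compound 4 (1.28 log units; beyond the scatter) and an at least 17-fold higher number from compound 1 to compound 4 (1.24 log units; beyond the scatter). Whichever of ethoxy, propoxy or methoxy leaves, the step is large, so this position accepts changes to the chain far more readily than this swap, which also removes the oxygen.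

The compounds shown cannot separate the effect of losing that oxygen from the effect of adding trifluoromethyl. On these data alone, how a plain methyl or an amine on the carbonyl carbon would behave remains open, and either could help to tell the two apart.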